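Indolyl oxadiazoline cinnamamides: fluorophenyl in place of nitrophenyl

This account rests on a few compounds, and the source may have more. Where it says the series, first, only, none or still open, it means among the compounds named here.

Compound 1 `O=C(/C=C\c1cccc([N+](=O)[O-])c1)N1N=C(c2ccncc2)OC1c1c[nH]c2ccccc12` is the starting point of this series in an ADME assay on PANC-1 cells (Homo sapiens) for cytotoxicity, read by MTT assay, with a stated time of 48 h; a lower number here means a stronger inhibitor of growth, a higher number a weaker inhibitor of growth. In this assay compound 1 gives only a limit, > 30 ug/mL. Compound 2 `O=C(/C=C\c1ccc([N+](=O)[O-])cc1)N1N=C(c2ccncc2)OC1c1c[nH]c2ccccc12` also gives a limit, > 30 ug/mL. Compound 3 `COc1ccc(/C=C\C(=O)N2N=C(c3ccncc3)OC2c2c[nH]c3ccccc23)cc1` likewise gives a limit, > 30 ug/mL. Going by the values given here, compound 1 thus stands where every value so far sits, at the limit of > 30 ug/mL in this assay, at which 3 of the 3 values shown sit, with no number resolved. Compound 4 `O=C(/C=C\c1ccc(F)cc1)N1N=C(c2ccncc2)OC1c1c[nH]c2ccccc12` differs from compound 1 in one place: 4-fluorophenyl in place of 3-nitrophenyl on a double-bonded chain carbon bound to a double-bonded chain carbon. The measured steps on the same aryl group, a step that the two limits leave unreadable from compound 1 to compound 2, a step that the two limits leave unreadable from compound 1 to compound 3 and a step that the two limits leave unreadable from compound 2 to compound 3, give no readable size because of the limit of > 30 ug/mL in this assay, at which 3 of the 3 values shown sit. The step that the limit leaves unreadable from compound 1 to compound 4 is therefore expected to show nothing beyond the scatter. Compound 4 is expected to remain near the same limit, estimated at 45 ug/mL, between 15 ug/mL and 150 ug/mL.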

Compound 4, concentration for 50% growth inhibition: > 30 ug/mL
Compound 4 gave a limit, no number (the forecaster's own chance of this, stated with the estimate: 80%); the middle value lies beyond the limit too.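

No step from compound 1, compound 2 or compound 3 to compound 4 can be read in this assay, because each value is a limit and not a number: the limit of > 30 ug/mL in this assay, at which 4 of the 4 values shown sit.

The compounds shown leave open how strongly any of these aryl variants inhibits growth in this assay.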